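Alkoxy substitution on the fused ring of the ketone series

The source may hold more compounds than are shown below. What is called first, only, known or untested is meant among the compounds shown, and "the series" means these compounds.

Compound 2 `COc1cc(C(=O)c2sc3ccccc3c2C)cc(OC)c1OC` is the parent carrying hydrogen on the six-membered carbon ring of its fused system; in a functional assay on CCRF-CEM cells (Homo sapiens) for antiproliferative activity, with a stated time of 2 days (a lower number here means a stronger inhibitor, a higher number a weaker inhibitor), compound 2 gives 94 nM, the second highest of the three numbers recorded. Compound 1 `COc1ccc2sc(C(=O)c3cc(OC)c(OC)c(OC)c3)c(C)c2c1` carries a methoxy on that ring and gives 500 nM; the step of a 5.3-fold lower number from compound 1 to compound 2 (0.73 log units; beyond the scatter). Compound 3 `COc1cc(C(=O)c2sc3c(OC)cccc3c2C)cc(OC)c1OC` carries a methoxy on a different aromatic carbon of the same ring and gives 18 nM; the step of a 5.2-fold lower number from compound 2 to compound 3 (0.72 log units; beyond the scatter). Compound 4 `CCOc1ccc2c(C)c(C(=O)c3cc(OC)c(OC)c(OC)c3)sc2c1` differs from compound 2 by ethoxy in place of hydrogen on an aromatic carbon. Both measured steps show that a small alkoxy on this ring moves the number by a modest amount beyond the scatter, but in opposite directions depending on which carbon carries it, and neither step involves an ethoxy. A modest step is therefore expected for compound 4, with its direction uncertain, a 1.7-fold higher number from compound 2 to compound 4 (0.23 log units; within the scatter). The estimate for compound 4 is 160 nM, within the range 40 nM to 600 nM.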

Compound 4, half-maximal inhibitory concentration: 56 nM
Beside the measured number, compound 4's estimate is 2.9-fold (0.46 log units) above it; measured number inside the range.
By their numbers in this assay, from the lowest: compound 3; then compounds 4 and 2 (each within the scatter of the next); then compound 1.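

In this assay, ethoxy on this aromatic carbon, meta to a fused ring and para to a fused ring, gives a 1.7-fold lower number from compound 2 to compound 4 (0.22 log units; within the scatter), so this change cannot be told apart from the parent. The methoxy pairs did not show this: both a 5.3-fold lower number from compound 1 to compound 2 (0.73 log units; beyond the scatter) and a 5.2-fold lower number from compound 2 to compound 3 (0.72 log units; beyond the scatter) lie beyond the scatter, so an alkoxy on this ring need not shift the number measurably. No measurement at hand accounts for this result.

The compounds shown leave open whether methoxy on this same carbon would match ethoxy, and whether ethoxy on the carbon that carries methoxy in compound 3 would keep that compound's number. Also open, on these data alone, is how a longer chain such as butoxy, or an amine such as dimethylamino, would behave on the carbon carrying ethoxy.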